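A few compounds are considered here, and "the series" means these few. Any claim that something is new, unique, unknown or untested is made for them only; others in the source may bear on it.

Measured compounds:
compound 1 `COc1ccccc1/C=c1/[nH]c(=O)/c(=C\c2ccccc2OC)n(C)c1=O`, a functional assay on HeLa cells (Homo sapiens) for cytotoxicity, read by CCK-8 assay, with a stated time of 72 h; a lower number here means a stronger inhibitor, a higher number a weaker inhibitor: "not active" (no number reported)
compound 2 `C=CCn1c(=O)/c(=C\c2cccc(Cl)c2Cl)[nH]c(=O)/c1=C\c1ccccc1OC`, this assay: 1600 nM

Compound 2 carries the only number shown in this assay; the further entry, compound 1, is reported without one. Compound 3 `COc1ccccc1/C=c1\c(=O)[nH]/c(=C/c2cccc(Cl)c2Cl)c(=O)n1C` differs from compound 2 by hydrogen in place of vinyl on a saturated chain carbon bound to an aromatic nitrogen, which amounts to allyl to methyl. Among the measured compounds shown here, no step between measured compounds is available to calibrate this change, so a modest move toward weaker inhibition is expected, a 1.6-fold higher number from compound 2 to compound 3 (0.19 log units; within the scatter). Compound 3 is therefore estimated at 2500 nM, with a range of 900 nM to 8000 nM.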

Compound 3, half-maximal inhibitory concentration: 200 nM
Estimate against measurement, compound 3: 13-fold (1.10 log units) above; the measured number lies below the stated range.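

In this assay, the group on the saturated chain carbon bound to an aromatic nitrogen proves to matter: going from allyl to methyl, hydrogen in place of vinyl, gives an 8.0-fold lower number from compound 2 to compound 3 (0.90 log units; beyond the scatter) with the rest of the structure unchanged. The allyl group is therefore not required for activity in this pair, and the shorter methyl is the better of the two. Nothing shown here accounts for this gain in strength.

As far as these compounds go, it remains open whether an ethyl group, a longer chain or a chain ending in an amine would continue this trend. A single step also cannot show whether the same change would hold with other aryl groups on the shared core.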